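This account rests on a few compounds, and the source may have more. Where it says the series, first, only, none or still open, it means among the compounds named here.

Measured so far:
Compound 1 `CCCCCCCCOc1ccc(NC(=O)Oc2ccccc2F)cc1` gives 19 nM in an assay on H4 cells for inhibition of Fatty-acid amide hydrolase 1 (Homo sapiens); a higher number here means a weaker inhibitor, a lower number a stronger inhibitor.
Compound 2 `CCCCOc1ccc(C(CC)NC(=O)Oc2cccc(N(C)C)c2)cc1` gives 54 nM in this assay.
Compound 3 `CCCCOc1ccc(C(CC)NC(=O)Oc2ccc(F)cc2F)cc1` gives 21 nM in this assay.

Compound 3 thus sits between the other two: its number lies close to that of compound 1, within the usual scatter, and clearly below that of compound 2. Compound 4 `CCCCOc1ccc(C(CC)NC(=O)Oc2ccc(OC)cc2)cc1` has not yet been measured. The change is 4-methoxyphenyl in place of 2,4-difluorophenyl on an oxygen next to a carbonyl group. Within the data shown here, the one measured step at this place is a 2.6-fold lower number from compound 2 to compound 3 (0.41 log units; beyond the scatter), where a ring carrying a dimethylamino group gave way to the difluoro ring and the number fell. Compound 4 undoes part of that move, swapping the two fluorines for a methoxy group. For compound 4 a modest rise in this assay is therefore expected, a 2.1-fold higher number from compound 3 to compound 4 (0.33 log units; beyond the scatter). Compound 4 is estimated at 45 nM, with a range from 20 nM to 110 nM.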

Compound 4, half-maximal inhibitory concentration: 12 nM
Compound 4: the middle estimate sits 3.8-fold (0.57 log units) above what was measured; the whole stated range lies above it.
By their numbers in this assay, from the lowest: compounds 4, 1 and 3 (each within the scatter of the next); then compound 2.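

In this assay the 4-methoxyphenyl group serves on this oxygen as well as 2,4-difluorophenyl, with a 1.8-fold lower number from compound 3 to compound 4 (0.24 log units; within the scatter), so the fluorines are not needed for a low number among these compounds. Set against the 3-(dimethylamino)phenyl group, the same change gives a 4.5-fold lower number from compound 2 to compound 4 (0.65 log units; beyond the scatter), so a second, quite different ring also reaches the lower range. Nothing available explains why these rings match. Still open, as far as these compounds go, is how an unsubstituted phenyl ring would compare, and whether an ethoxy group or a carboxylic acid could take the place of the methoxy group.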